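The source may report more compounds than this note shows. Statements on the series, on what has been measured and on what is new or still open speak of the compounds shown alone.

Measured so far:
compound 1, `CC1=C(N2CC2)C(=O)C(N2CC2)=C(N2CC2)C1=O`: 5.69
compound 2, `CCC(COC(N)=O)C1=C(N2CC2)C(=O)C(C)=C(N2CC2)C1=O`: 5.2
compound 3, `CC(C)C1=C(N2CC2)C(=O)C=C(N2CC2)C1=O`: 4.59

Three compounds of the shared core have been run in a functional assay on L1210 cells (Mus musculus), with a stated time of 1 days; a lower number here means a less potent compound, a higher number a more potent compound, by a factor of ten per unit of this negative logarithm. Compound 1 stands highest of the three, with compound 2 a step below that is beyond the scatter and compound 3 further below, also beyond the scatter. Compound 1 carries three aziridin-1-yl groups; compound 2 and compound 3 each carry two.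

Compound 4, `CC1=C(N2CC2)C(=O)C(CCCOC(N)=O)=C(N2CC2)C1=O`, is not yet measured. It comes from compound 1 by the change (a group of 7 heavy atoms (4 carbon, 1 nitrogen, 2 oxygen; no ring) in place of a group of 3 heavy atoms (2 carbon, 1 nitrogen; one three-membered non-aromatic ring with 1 hetero atom), on a double-bonded ring carbon). Going by the values given here, no measured pair shows this exact step. Compound 2, which also carries two aziridin-1-yl groups and a carbamate-bearing chain, gives 5.2 in this assay, and compound 4 is expected to land in that neighbourhood, a step down from compound 1 of a number 0.44 log units lower from compound 1 to compound 4 (beyond the scatter), beyond the scatter. The estimate for compound 4 is 5.25, within 4.65 to 5.85.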

Compound 4, logarithm of the reciprocal of the active concentration, log(1/C): 5.48
Compound 4: middle estimate off by 0.23 log units, on the low side; measured number inside the range.
By their numbers in this assay, from the lowest: compound 3; then compounds 2, 4 and 1 (each within the scatter of the next, the first and the last beyond it).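

In this assay, the chain of 7 heavy atoms in place of an aziridin-1-yl group gives a number 0.21 log units lower from compound 1 to compound 4 (within the scatter). At this double-bonded ring carbon, then, an aziridin-1-yl group can give way to a chain with no ring without a step beyond the scatter, with the other two aziridin-1-yl groups kept. No accompanying measurement offers a reason for this result.

From the compounds shown here alone, whether a shorter chain at this carbon would also stay within the scatter remains open. So does the outcome with a chain ending in an amine or a carboxylic acid in place of the carbamate.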